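The compounds below may be only part of what the source reports. "The series", "measured", "known", "first", "only" and "open" are said of these compounds alone.

Compound 3 `Cc1ccc(-c2sc(N)c(C(=O)c3ccc(Cl)cc3)c2CC(C)(C)C)cc1` gives 1% in an assay on CHO cells for displacement of a labelled ligand from adenosine receptor A3 (Homo sapiens), read by scintillation counting, tested at 10 uM; on this read-out lower numbers stand for less inhibition and higher numbers for more inhibition at the one concentration tested (going by the name of the read-out). It stands level with compound 1 `COc1ccc(-c2sc(N)c(C(=O)c3ccc(Cl)cc3)c2C)cc1`, which gives 1%, the two together being the lowest of the three numbers measured, while compound 2 `CC(C)(C)Cc1c(-c2ccncc2)sc(N)c1C(=O)c1ccc(Cl)cc1` gives 6%. Going by the values given here, the one measured step that touches this series, a number 5 percentage points lower from compound 2 to compound 3 (within the scatter), lies within the scatter. Compound 4 `COc1ccc(-c2sc(N)c(C(=O)c3ccc(Cl)cc3)c2CC(C)(C)C)cc1` differs from compound 3 by methoxy in place of methyl on an aromatic carbon. Among the compounds with values here, no measured step matches this change; compound 1 carries a methoxyphenyl group and compound 3 a methylphenyl group, but they also differ elsewhere, so only their two values, both low, can be noted. Compound 4 is therefore expected to give about 2%, within 0% to 12%, a step of a number 1 percentage points higher from compound 3 to compound 4 (within the scatter) that is estimated to stay within the scatter.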

Compound 4, a percentage reported as inhibition, at one concentration (the size of the read-out at that concentration, not a potency): 2%
Beside the measured number, compound 4's estimate shows no gap at the digits printed; the range from low to high includes it.
By their numbers in this assay, from the lowest: compounds 1, 3, 4 and 2 (each within the scatter of the next).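

In this assay, methoxy in place of methyl on this aromatic carbon, para to a large group, gives a number 1 percentage points higher from compound 3 to compound 4 (within the scatter) and so leaves the read-out unmoved. The two other single changes read alike, with 4-methoxyphenyl in place of pyridin-4-yl giving a number 4 percentage points lower from compound 2 to compound 4 (within the scatter) and tert-butyl in place of hydrogen on the saturated chain carbon giving a number 1 percentage points higher from compound 1 to compound 4 (within the scatter) at the same low level. Nothing available explains these numbers. Going by these compounds, whether an amine or a carboxylic acid at this position would raise the inhibition stays open. All four compounds sit low, so the compounds shown do not tell which places matter.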